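This account rests on a few compounds, and the source may have more. Where it says the series, first, only, none or still open, it means among the compounds named here.

In an ADME assay on microsomes from liver (Rattus norvegicus) for metabolic stability, read by LC-MS, using NADPH, at 37 degrees C (a higher number here means that the compound lasts longer, a lower number that the compound disappears faster), compound 1, with the structure `Cc1cc(C)c(-c2nc(CN3CCC(C(=O)NCCCN4C[C@H](C)C[C@H](C)C4)CC3)c(C)o2)c(C)c1`, stands at a limit of the assay rather than at a number, giving > 0.5 h. Compound 3, with the structure `Cc1ccccc1-c1nc(CN2CCC(C(=O)N3CCN(CCN(C)C)CC3)CC2)c(C)o1`, also sits at a limit in this assay, at > 0.5 h. Compound 2, with the structure `Cc1cccc(Cl)c1-c1nc(CN2CCC(C(=O)NCCCN3CCC(C(C)C)CC3)CC2)c(C)o1`, is the only one of the three that gives a number in this assay, at 0.0333 h. The picture is thus shaped by the limit of > 0.5 h in this assay, at which 2 of the 3 values shown sit, so that compound 1 cannot be ranked against compound 3 and only stands apart from compound 2.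

Compound 4, with the structure `Cc1ccc(-c2nc(CN3CCC(C(=O)NCCCN4C[C@H](C)C[C@H](C)C4)CC3)c(C)o2)cc1`, differs from compound 1 in one place: 4-methylphenyl in place of 2,4,6-trimethylphenyl on an aromatic carbon. For the measured compounds named here, no measured pair shows this kind of change, so its effect in this assay is not known from the data. The step from compound 1 to compound 4 is expected to be small, an at least 1.2-fold lower number from compound 1 to compound 4 (0.09 log units; that floor lies within the scatter), within the scatter or slightly downward. Compound 4 is therefore estimated at 0.4 h in this assay, with a range from 0.1 h to 1.5 h.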

Compound 4, half-life: > 0.5 h
Compound 4 was reported as a limit (the forecaster's own chance of this, stated with the estimate: 40%); at least 1.2-fold (0.09 log units) between middle value and limit.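

In this assay compound 4 gives > 0.5 h, a limit and not a number, and compound 1 also stands at a limit, so no step can be read between compound 1 and compound 4: the limit of > 0.5 h in this assay, at which 3 of the 4 values shown sit.

What the compounds shown leave open is whether 4-methylphenyl in place of 2,4,6-trimethylphenyl changes the half-life in this assay at all.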